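The source may hold more compounds than are shown below. What is called first, only, known or untested is meant among the compounds shown, and "the series" means these compounds.

Compound 1 `CN(CC1=CC[C@H]2C[C@@H]1C2(C)C)Cc1ccccc1I`: 5010 nM
Compound 2 `CN(CC1=CC[C@H]2C[C@@H]1C2(C)C)Cc1ccccc1`: 15800 nM
Compound 3 `CN(CC1=CC[C@H]2C[C@@H]1C2(C)C)Cc1cccc(-c2ccccc2)c1`: a limit, > 316 nM

In an assay on HEK293 cells for displacement of a labelled ligand from C-X-C chemokine receptor type 3 (Homo sapiens) (a higher number here means a weaker inhibitor, a lower number a stronger inhibitor), compound 2 gives 15800 nM, the highest of the two numbers available. The nearest is compound 1, which gives 5010 nM; the step between them is a 3.2-fold higher number from compound 1 to compound 2 (0.50 log units; beyond the scatter). Compound 3 gives only a limit of the assay, > 316 nM. The step that the limit leaves unreadable from compound 2 to compound 3 therefore has no readable size, as the value sits at the limit of > 316 nM in this assay, at which 1 of the 3 values shown sits.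

Compound 4 `CN(CC1=CC[C@H]2C[C@@H]1C2(C)C)Cc1ccc(-c2cccc([N+](=O)[O-])c2)cc1` differs from compound 2 by 3-nitrophenyl in place of hydrogen on an aromatic carbon. Going by the values given here, two measured steps bear on this change. The step from compound 1 to compound 2 shows that taking a group off the ring raises the number modestly, so putting a group on is expected to lower it. The step to compound 3, which also puts an aromatic group on an aromatic carbon, ends at a limit and gives no size. A lower number is thus expected for compound 4, of uncertain size. Compound 4 is estimated at 3000 nM, range 800 nM to 12000 nM. The step of a 5.3-fold lower number from compound 2 to compound 4 (0.72 log units; beyond the scatter) is the expected outcome.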

Compound 4, inhibition constant: 2000 nM
Compound 4: the middle estimate sits 1.5-fold (0.18 log units) above what was measured; the range from low to high includes it.
By their numbers in this assay, from the lowest: compound 4; then compound 1; then compound 2.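

In this assay, 3-nitrophenyl on an aromatic carbon para to a large group gives a readable size for an added aromatic ring on this ring: a 7.9-fold lower number from compound 2 to compound 4 (0.90 log units; beyond the scatter). The number falls, so this large group, with its one six-membered aromatic ring of carbon only, is tolerated at this place and does not cost affinity. The step to compound 3 cannot be read, as compound 3 gives only a limit and not a number: the limit of > 316 nM in this assay, at which 1 of the 4 values shown sits.

Open, from the compounds shown here alone, is how much of the step belongs to the added ring and how much to the nitro group. An unsubstituted phenyl at this same place, or a ring carrying an amine or a carboxylic acid in place of the nitro group, would separate the two.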